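Swapping Methyl for Fluoro on the Acid Chain

The source may hold more compounds than are shown below. What is called first, only, known or untested is meant among the compounds shown, and "the series" means these compounds.

In an ADME assay on the whole organism (Rattus norvegicus, strain Sprague-Dawley) for pharmacokinetics, read by LC-MS, at a dose of 10 mg/kg by the oral route (on this read-out lower numbers stand for lower oral bioavailability and higher numbers for higher oral bioavailability), compound 1 (`COc1ccc(F)c([C@H]2CC[C@H](COc3cccc([C@@H](CC(=O)O)C4CC4)c3)CC2)c1`) gives 91.4% and compound 2 (`COc1ccc(F)c([C@H]2CC[C@H](COc3cccc([C@H](C4CC4)[C@H](C)C(=O)O)c3)CC2)c1`) gives 45.5% as the lower of the two numbers. Within the data shown here, the only measured step is a number 45.9 percentage points lower from compound 1 to compound 2 (beyond the scatter) for methyl in place of hydrogen on a saturated chain carbon bound to a carbonyl carbon and a saturated chain carbon. It is large and beyond the scatter.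

Compound 3 (`COc1ccc(F)c([C@H]2CC[C@H](COc3cccc([C@H](C4CC4)[C@@H](F)C(=O)O)c3)CC2)c1`) is not yet measured. Its difference from compound 2 is carboxy(fluoro)methyl in place of 1-carboxyethyl on a saturated chain carbon bound to an aromatic carbon and a saturated ring carbon in full, that is, carboxy(fluoro)methyl in place of 1-carboxyethyl on a saturated chain carbon bound to an aromatic carbon and a saturated ring carbon. Among the measured compounds shown here, the measured step bears on this only in part: the fluoro group replaces the same methyl, and no measured compound carries carboxy(fluoro)methyl. Removing that methyl may therefore recover part of the large step, though not all of it. The expected change is a number 14.5 percentage points higher from compound 2 to compound 3 (beyond the scatter) as a moderate rise with wide uncertainty. Compound 3 is estimated at 60% within an expected range from 30% to 85% on this evidence.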

Compound 3, oral bioavailability: 73.8%
Estimate against measurement, compound 3: 13.8 percentage points below, within the range that was stated.
By their numbers in this assay, from the lowest: compound 2; then compound 3; then compound 1.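

With carboxy(fluoro)methyl in place of 1-carboxyethyl, this assay gives a number 28.3 percentage points higher from compound 2 to compound 3 (beyond the scatter) on a saturated chain carbon bound to an aromatic carbon and a saturated ring carbon, which shows that the number at this place depends on which group sits on the acid chain, and not merely on whether the hydrogen has been replaced. Set against the unsubstituted chain, fluoro in place of hydrogen gives a number 17.6 percentage points lower from compound 1 to compound 3 (beyond the scatter) and so does not restore the full number, which places the fluoro change as a smaller loss than the methyl change among these three compounds, though still a loss beyond the scatter. Nothing available here bears on why the methyl and fluoro groups part in this way, and the three numbers stand without an explanation.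

The compounds shown leave open where other groups on this same carbon would fall, such as chloro, hydroxy or a second fluoro, and whether the order seen here would hold for them. They also leave open what the opposite configuration at the fluorine-bearing carbon would give, and whether the same order would appear with a different group in place of the cyclopropyl ring.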